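Dropping One Fluorine From the Sulfonyl Ring

The compounds below may be only part of what the source reports. "The series", "measured", "known", "first", "only" and "open" are said of these compounds alone.

Measured in a functional assay on K562 cells (Homo sapiens) for inhibition, read by trypan blue exclusion, with a stated time of 72 h; a lower number here means a stronger inhibitor, a higher number a weaker inhibitor:
compound 1 `Cn1c(=O)c(S(=O)(=O)c2ccc(F)cc2F)cc2cnc(Nc3ccc4cc[nH]c4c3)nc21`: 5000 nM
compound 2 `Cn1c(=O)c(S(=O)(=O)c2ccc(F)cc2F)cc2cnc(Nc3ccc4[nH]c(C(=O)O)cc4c3)nc21`: 10000 nM
compound 3 `Cn1c(=O)c(S(=O)(=O)c2ccc(F)cc2F)cc2cnc(Nc3ccc4[nH]ncc4c3)nc21`: 50000 nM

Compound 1 gives the lowest number of the three. Its gap to compound 2 is small, a 2.0-fold higher number from compound 1 to compound 2 (0.30 log units; within the scatter), while the gap to compound 3 is larger, a 10-fold higher number from compound 1 to compound 3 (1.00 log units; beyond the scatter). Compound 4 `Cn1c(=O)c(S(=O)(=O)c2ccc(F)cc2)cc2cnc(Nc3ccc4cc[nH]c4c3)nc21` keeps the shared core of compound 1 and changes only the sulfonyl side: hydrogen in place of fluoro on an aromatic carbon. Within the data shown here, every measured step, including a 5.0-fold higher number from compound 2 to compound 3 (0.70 log units; beyond the scatter), alters the group attached to the amine nitrogen, and none touches the sulfonyl ring, so no measured step bears directly on this change. With nothing pointing either way, the expected step is one within the scatter, no change at the digits printed from compound 1 to compound 4 (within the scatter). Compound 4 is therefore estimated at 5000 nM, with a range from 2000 nM to 15000 nM.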

Compound 4, half-maximal inhibitory concentration: 10000 nM
The estimate for compound 4 lay 2.0-fold (0.30 log units) below the measured number; low and high end bracket the measured number.
By their numbers in this assay, from the lowest: compounds 1, 2 and 4 (each within the scatter of the next); then compound 3.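

In this assay, among these compounds, the sulfonyl ring can now be read for the first time: the change from 2,4-difluorophenyl to 4-fluorophenyl gives a 2.0-fold higher number from compound 1 to compound 4 (0.30 log units; within the scatter) and so no real difference. The fluoro group ortho to a large group can therefore be replaced by hydrogen here without a clear gain or loss on this indole-bearing compound. Nothing available explains this result.

From the compounds shown here alone, whether a larger group at this place, such as chloro or methoxy, would move the number remains open. So does the role of the remaining fluoro group, and whether hydrogen is tolerated as well with the other amine substituents.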